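A few compounds are considered here, and "the series" means these few. Any claim that something is new, unique, unknown or untested is made for them only; others in the source may bear on it.

Three compounds have numbers in an assay on MDA-MB-231 cells for binding affinity to C-X-C chemokine receptor type 4 (Homo sapiens), read by fluorescence and microscopy, with stated times of 10 min and 30 min (on this read-out higher numbers stand for an effect only at larger amounts of compound and lower numbers for an effect already at smaller amounts), so far. Compound 1 `O=C(NCc1ccc(CNS(=O)(=O)c2cccc(C(F)(F)F)c2)cc1)c1ccc(F)cc1` gives 100 nM in this assay. Compound 2 `Cc1ccc(S(=O)(=O)NCc2ccc(CNC(=O)c3ccc(F)cn3)cc2)cc1` gives 1000 nM in this assay, and compound 3 `O=C(NCc1ccc(CNS(=O)(=O)c2ccc(CN3CCCC3)cc2)cc1)c1ccc(F)cc1` gives 1 nM in this assay. Compound 1 therefore stands second highest of the three: compound 2 sits a full step above it, beyond the scatter, and compound 3 sits far below it, also beyond the scatter. Compounds 2 and 3 each differ from compound 1 in more than one place, so no single change can be read off from them.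

Compound 4 `Cc1ccccc1S(=O)(=O)NCc1ccc(CNC(=O)c2ccc(F)cc2)cc1` has not yet been measured in this assay. It differs from compound 1 in one place: 2-methylphenyl in place of 3-(trifluoromethyl)phenyl on a sulfonyl sulfur. Going by the values given here, no step of this kind has been measured, so the expectation rests on compound 1 alone. Compound 4 is expected to come out somewhat weaker than compound 1, with a step of a 3.0-fold higher number from compound 1 to compound 4 (0.48 log units; beyond the scatter) that may not exceed the scatter. The estimate for compound 4 in this assay is 300 nM, within a range from 60 nM to 1500 nM.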

Compound 4, effective concentration (reported as EC, without a stated level of effect): 100 nM
Estimate against measurement, compound 4: 3.0-fold (0.48 log units) above, within the range that was stated.
By their numbers in this assay, from the lowest: compound 3; then compounds 1 and 4 (each within the scatter of the next); then compound 2.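

In this assay, placing 2-methylphenyl in place of 3-(trifluoromethyl)phenyl on a sulfonyl sulfur gives no change at the digits printed from compound 1 to compound 4 (within the scatter). Going by these compounds alone, this is the first single change that can be read here, and it shows that, with the rest of compound 1 held fixed, this place tolerates going from 10 heavy atoms with 3 fluorine to 7 heavy atoms with only carbon, while one six-membered aromatic ring stays on the sulfur. No measurement at hand explains why the two groups give such similar numbers.

The swap alters both the substituent and where it sits on the ring, so the two effects cannot be separated. As far as these compounds go, it also remains open whether a plain phenyl, a ring carrying a carboxylic acid, or a longer alkyl chain in place of the ring would fit equally well.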